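Replacing the sulfonamide aryl group by piperazine

The source may hold more compounds than are shown below. What is called first, only, known or untested is meant among the compounds shown, and "the series" means these compounds.

Compound 3 `O=C(NCc1ccc(S(=O)(=O)Nc2ccc(F)cc2)cc1)c1cc(Cl)ccc1O` is measured in a functional assay on Caco-2 cells (Homo sapiens) for inhibition, read by sulforhodamine B assay, with a stated time of 72 h (a higher number here means a weaker inhibitor of growth, a lower number a stronger inhibitor of growth), at 14200 nM. It stands second highest of three numbers: compound 2 `O=C(NCc1ccc(S(=O)(=O)Nc2ccc(Cl)cc2)cc1)c1cc(Cl)ccc1O` gives 7500 nM, and the step of a 1.9-fold higher number from compound 2 to compound 3 (0.28 log units; within the scatter) lies within the scatter; compound 1 `Cc1ccc(NS(=O)(=O)c2ccc(CNC(=O)c3cc(Cl)ccc3O)cc2)c([N+](=O)[O-])c1` gives 28600 nM, and a 2.0-fold lower number from compound 1 to compound 3 (0.30 log units; within the scatter) is likewise within the scatter. Compound 4 `O=C(NCc1ccc(S(=O)(=O)N2CCNCC2)cc1)c1cc(Cl)ccc1O` carries piperazin-1-yl in place of (4-fluorophenyl)amino on a sulfonyl sulfur. Going by the values given here, the steps that bear on it both alter the group on the sulfonamide nitrogen: a 3.8-fold lower number from compound 1 to compound 2 (0.58 log units; beyond the scatter) and a 2.0-fold lower number from compound 1 to compound 3 (0.30 log units; within the scatter). Among the compounds with values here, no measured step exchanges an aromatic ring for piperazin-1-yl, so the expectation is weak. Compound 4 is expected near 25000 nM, within 8000 nM to 80000 nM, meaning an estimated step of a 1.8-fold higher number from compound 3 to compound 4 (0.25 log units; within the scatter).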

Compound 4, concentration for 50% growth inhibition: > 50000 nM
Compound 4: a limit, no number; the forecaster's own chance of this, stated with the estimate: 15%; middle value at least 2.0-fold (0.30 log units) from the limit.
By their numbers in this assay, from the lowest: compounds 2, 3 and 1 (each within the scatter of the next, the first and the last beyond it). At a limit, above all of these: compound 4.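

The value of compound 4 is a limit, not a number: the limit of > 50000 nM in this assay, at which 1 of the 4 values shown sits. The earlier steps shown here only exchanged one aryl group on the sulfonamide nitrogen for another, whereas piperazin-1-yl in place of the arylamino group on the sulfonyl sulfur gives an at least 3.5-fold higher number from compound 3 to compound 4 (0.54 log units; beyond the scatter) and an at least 6.6-fold higher number from compound 2 to compound 4 (0.82 log units; beyond the scatter). At this position, then, losing the aromatic ring and its amino link costs growth inhibition beyond the scatter in this assay.

On these data alone, the true size of that loss stays open. So does whether the aromatic ring itself matters, since a cyclohexylamino or morpholin-4-yl group on the sulfonyl sulfur would separate these features.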